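Fluoro Substitution on an Aryl Hydroxamic Acid Series

This account rests on a few compounds, and the source may have more. Where it says the series, first, only, none or still open, it means among the compounds named here.

Working notes. Compound 1 `CCCCCCc1ccc(COc2cccc(C(=O)NO)c2)cc1` gives 2110 nM in an assay on isolated protein for inhibition of sphingomyelin phosphodiesterase (Homo sapiens), read by fluorescence, with a stated time of 30 min; a higher number here means a weaker inhibitor, a lower number a stronger inhibitor. Compound 2 `O=C(NO)c1cccc(OCc2ccc(-c3noc(-c4ccccc4)n3)cc2)c1` gives > 100000 nM in this assay, which is a limit of the assay and not a number. Compound 2 therefore stands at the limit of > 100000 nM in this assay, at which 1 of the 2 values shown sits, and cannot be ranked against compound 1 beyond that. Compound 3 `O=C(NO)c1cccc(OCc2ccc(-c3noc(-c4ccccc4F)n3)cc2)c1` has not yet been measured in this assay. It differs from compound 2 by fluoro in place of hydrogen on an aromatic carbon, ortho to a large group, phenyl becoming 2-fluorophenyl. Going by the values given here, no step between measured compounds is available to calibrate a change of this kind. The expectation is that the step of a number no higher from compound 2 to compound 3 (the limit leaves the size open) stays within the usual scatter, with no clear direction, so compound 3 is expected to remain at or near the limit. The estimate for compound 3 in this assay is 100000 nM, within a range of 30000 nM to 300000 nM.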

Compound 3, half-maximal inhibitory concentration: > 100000 nM
Compound 3: a limit, no number (the forecaster's own chance of this, stated with the estimate: 70%); the middle value lies on the limit itself.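

No step can be read between compound 2 and compound 3, since each gives a limit of the assay and not a number: the limit of > 100000 nM in this assay, at which 2 of the 3 values shown sit.

Left open is whether fluoro in place of hydrogen, phenyl becoming 2-fluorophenyl, changes inhibition at all, and how far either compound lies beyond the limit.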